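Working notes: from compound 1 to compound 4

This account rests on a few compounds, and the source may have more. Where it says the series, first, only, none or still open, it means among the compounds named here.

Measured compounds:
compound 1 `C=C(Br)C(=O)Nc1cccc(/C=C/C(=O)Nc2ccc(F)cc2)c1`: 4800 nM
compound 2 `C=C(Br)C(=O)Nc1cccc(/C=C/C(=O)Nc2cccc(F)c2)c1`: 1000 nM
compound 3 `C=C(Br)C(=O)Nc1cccc(/C=C/C(=O)NCc2ccc(C)cc2)c1`: 1900 nM

All three values come from a functional assay on LoVo cells (Homo sapiens) for inhibition, read by MTT assay, with a stated time of 72 h; on this read-out higher numbers stand for weaker inhibition and lower numbers for stronger inhibition. Compound 1, at 4800 nM, gives the highest number of the three, and its steps to the other two both lie beyond the scatter. The compound awaiting measurement is compound 4 `C=C(Br)C(=O)Nc1cccc(/C=C/C(=O)Nc2ccc(SC(F)(F)F)cc2)c1`. The structural change from compound 1 is (trifluoromethyl)sulfanyl in place of fluoro on an aromatic carbon, para to a large group.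

Two measured steps alter the group on the amide-type nitrogen of compound 1. They are a 4.8-fold lower number from compound 1 to compound 2 (0.68 log units; beyond the scatter) and a 2.5-fold lower number from compound 1 to compound 3 (0.40 log units; beyond the scatter), both modest and both toward lower numbers. The remaining step, a 1.9-fold higher number from compound 2 to compound 3 (0.28 log units; within the scatter), separates nothing beyond the scatter. Among the compounds with values here, no measured compound carries (trifluoromethyl)sulfanyl, so these steps are only a loose guide, and a step to a higher number cannot be excluded. With a 2.5-fold lower number from compound 1 to compound 3 (0.40 log units; beyond the scatter) as the smaller of the two, a modest step to a lower number is expected in this assay. The expected step is a 2.4-fold lower number from compound 1 to compound 4 (0.38 log units; beyond the scatter). For compound 4 the estimated value is 2000 nM, with an expected range of 700 nM to 6000 nM.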

Compound 4, half-maximal inhibitory concentration: 29300 nM
For compound 4 the middle estimate is 15-fold (1.17 log units) below the measured one, outside the stated range (above it).
By their numbers in this assay, from the lowest: compounds 2 and 3 (each within the scatter of the next); then compound 1; then compound 4.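

In this assay, the aromatic carbon para to a large group proves sensitive to substitution: a 6.1-fold higher number from compound 1 to compound 4 (0.79 log units; beyond the scatter) is the only listed step from compound 1 toward a higher number. The two earlier steps from compound 1 changed the group on the amide-type nitrogen and both went toward lower numbers, so their direction does not carry over to this aromatic carbon. Here, (trifluoromethyl)sulfanyl, with 5 heavy atoms, replaces fluoro, with 1 heavy atom, and weakens inhibition on this read-out, but no measured property is available to account for that loss.

With a single replacement at this carbon, the compounds shown cannot tell whether the higher number is specific to (trifluoromethyl)sulfanyl or would appear with other groups larger than fluoro. A chloro, methyl, methoxy or trifluoromethyl group on the same carbon would help separate these possibilities, and an unsubstituted ring would show what fluoro itself contributes to the value of compound 1.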